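Series notes: anilino replacement for (thiophen-3-yl)methyl on the core

The source may hold more compounds than are shown below. What is called first, only, known or untested is meant among the compounds shown, and "the series" means these compounds.

Measured so far:
compound 1 `Cc1cc(Cc2cccc(F)c2)c(=O)n(CC(=O)Nc2ccc(Br)cc2)n1` in a functional assay on HL-60 cells (Homo sapiens), read by calcium flux (on this read-out lower numbers stand for an effect already at smaller amounts and higher numbers for an effect only at larger amounts of compound), gives > 50000 nM, a limit.
compound 2 `Cc1cc(Cc2ccsc2)c(=O)n(CC(=O)Nc2ccc(Br)cc2)n1` gives > 50000 nM, a limit.
compound 3 `Cc1cc(Cc2cccc3ccccc23)c(=O)n(CC(=O)Nc2ccc(Br)cc2)n1` gives > 50000 nM, a limit.

All three values sit at the assay limit (the limit of > 50000 nM in this assay, at which 3 of the 3 values shown sit), so the steps a step that the two limits leave unreadable from compound 1 to compound 2, a step that the two limits leave unreadable from compound 1 to compound 3 and a step that the two limits leave unreadable from compound 2 to compound 3 cannot be sized. Compound 2 therefore stands at a limit only, not at a number. Compound 4 `COc1ccc(Nc2cc(C)nn(CC(=O)Nc3ccc(Br)cc3)c2=O)cc1` differs from compound 2 by (4-methoxyphenyl)amino in place of (thiophen-3-yl)methyl on an aromatic carbon. Going by the values given here, none of the measured steps bears on a change of this kind; they show only that exchanging the aryl on the saturated chain carbon left every compound at the limit. The expected step of a number no higher from compound 2 to compound 4 (the limit leaves the size open) is of unknown direction, with a limit again the most likely outcome. Compound 4 is estimated at 50000 nM, within 5000 nM to 200000 nM.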

Compound 4, half-maximal effective concentration: > 50000 nM
Compound 4: no number, only a limit (the forecaster's own chance of this, stated with the estimate: 75%); the middle value lies on the limit itself.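

The steps from compound 1 and from compound 2 to compound 4 cannot be read, as every value shown is a limit: the limit of > 50000 nM in this assay, at which 4 of the 4 values shown sit. The compounds shown leave open whether any group on the shared core gives a number rather than a limit.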